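Swapping cyclohexyloxy for phenoxy on compound 3

The compounds below may be only part of what the source reports. "The series", "measured", "known", "first", "only" and "open" are said of these compounds alone.

Measured in a functional assay on HT-29 cells (Homo sapiens) for inhibition, read by sulforhodamine B assay, with a stated time of 48 h; a higher number here means a weaker inhibitor of growth, a lower number a stronger inhibitor of growth:
- compound 1 `c1cc(NC2=NCCO2)cc(OC2CCCCC2)c1` gives 4400 nM
- compound 2 `c1ccc(Oc2cccc(NC3=NCCO3)c2)cc1` gives 5500 nM
- compound 3 `O=C(CCl)NC(=O)Nc1cccc(OC2CCCCC2)c1` gives 3800 nM

Compound 3, at 3800 nM in this assay, lies within the usual scatter of both other compounds, so the three cannot be ranked. Compound 4 `O=C(CCl)NC(=O)Nc1cccc(Oc2ccccc2)c1` has not yet been measured. It differs from compound 3 in one place (phenyl in place of cyclohexyl on an oxygen on an aromatic ring): phenyl in place of cyclohexyl on an oxygen on an aromatic ring, or cyclohexyloxy to phenoxy.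

The same replacement has been measured once, with a 1.3-fold higher number from compound 1 to compound 2 (0.10 log units; within the scatter) as the result. The other measured step, a change of the group on a nitrogen on an aromatic ring, gave a 1.2-fold lower number from compound 1 to compound 3 (0.06 log units; within the scatter) and does not involve this replacement. For the measured compounds named here, with only that single small precedent, no change beyond the scatter is expected in this assay. The expected step is a 1.2-fold higher number from compound 3 to compound 4 (0.07 log units; within the scatter) and would be no more than a slight drift in the same direction. The estimate for compound 4 is 4500 nM in this assay, with an expected range from 2300 nM to 8500 nM for the measurement.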

Compound 4, concentration for 50% growth inhibition: 5200 nM
Compound 4: middle estimate off by 1.2-fold (0.06 log units), on the low side; the measured number falls inside the stated range.
By their numbers in this assay, from the lowest: compounds 3, 1, 4 and 2 (each within the scatter of the next).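

In this assay, phenyl in place of cyclohexyl on the oxygen now has a second reading, a 1.4-fold higher number from compound 3 to compound 4 (0.14 log units; within the scatter), which shows that the change stays small on a second core: the same change on two cores in this assay, a 1.3-fold higher number (0.10 log units; within the scatter) from compound 1 to compound 2 and a 1.4-fold higher number (0.14 log units; within the scatter) from compound 3 to compound 4, 1.1-fold (0.04 log units) apart, within the scatter of two such steps. The change of the group on the nitrogen also has a second reading, a 1.1-fold lower number from compound 2 to compound 4 (0.02 log units; within the scatter), and it stays equally small with phenoxy as with cyclohexyloxy: the same change on two cores in this assay, a 1.2-fold lower number (0.06 log units; within the scatter) from compound 1 to compound 3 and a 1.1-fold lower number (0.02 log units; within the scatter) from compound 2 to compound 4, 1.1-fold (0.04 log units) apart, within the scatter of two such steps. With all four corners of this small set now filled, neither change gives a step beyond the scatter on either core, and the two changes show no interplay.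

As far as these compounds go, it remains open whether a straight alkyl chain or a group carrying an amine, in place of cyclohexyl or phenyl on that oxygen, would give a step beyond the scatter in this assay. From the compounds shown here alone, it is equally open whether a carboxylic acid on the nitrogen's group would do so.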